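Fluoro to Methyl on the Benzyl Ring

The source may hold more compounds than are shown below. What is called first, only, known or untested is meant among the compounds shown, and "the series" means these compounds.

Compound 1, `CCN(Cc1ccccc1)C(=O)C1CCN(S(=O)(=O)c2ccc3cn[nH]c3c2)CC1`: 86%
Compound 2, `CCN(C(=O)C1CCN(S(=O)(=O)c2ccc(OC)cc2)CC1)[C@@H](C)c1ccccc1`: "not determined" (no result reported)
Compound 3, `CCN(Cc1cccc(F)c1)C(=O)C1CCN(S(=O)(=O)c2ccc3cn[nH]c3c2)CC1`: 89%

Three compounds share one core and differ at the group carried by the amide nitrogen. In a functional assay on CHO cells for positive allosteric modulation of muscarinic acetylcholine receptor M5 (Homo sapiens), read by calcium flux (on this read-out lower numbers stand for smaller maximal responses and higher numbers for larger maximal responses), compound 3 gives 89% and is the highest of the two numbers reported, while compound 1 gives 86%, which lies within the scatter of compound 3. For compound 2 the result in this assay is "not determined" (no result reported), so it adds nothing to the comparison.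

The next compound, compound 4, is `CCN(Cc1cccc(C)c1)C(=O)C1CCN(S(=O)(=O)c2ccc3cn[nH]c3c2)CC1`. It arises from compound 3 by the change (methyl in place of fluoro on an aromatic carbon).

Among the compounds with values here, only one measured step speaks to this: a number 3 percentage points higher from compound 1 to compound 3 (within the scatter). That step, a hydrogen giving way to fluoro at the same place, stayed within the scatter. Swapping fluoro for methyl at this place has no measured precedent here, and the one related step was flat, so no movement beyond the scatter is expected in this assay.

The expected step is therefore a number 1 percentage points lower from compound 3 to compound 4 (within the scatter), essentially no change. For compound 4 the estimated value is 88%, with a range from 74% to 102%.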

Compound 4, largest response reached (reported as percent of maximum), in percent of the reference or control that the assay uses: 78%
The estimate for compound 4 lay 10 percentage points above the measured number; measured number inside the range.
By their numbers in this assay, from the lowest: compounds 4, 1 and 3 (each within the scatter of the next, the first and the last beyond it).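

In this assay, within the data shown here, putting methyl where fluoro stood gives a number 11 percentage points lower from compound 3 to compound 4 (beyond the scatter) and is the first step at this place on the benzyl ring to leave the scatter, so this position is not wholly indifferent to what it carries. The picture stays narrow, though: methyl in place of hydrogen gives a number 8 percentage points lower from compound 1 to compound 4 (within the scatter) and fluoro in place of hydrogen gives a number 3 percentage points higher from compound 1 to compound 3 (within the scatter), so neither group separates clearly from hydrogen, and only the two groups differ from each other. No accompanying data on these compounds speak to what lies behind this small gap.

The compounds shown leave open how a chloro, methoxy or trifluoromethyl group at this same place would read, and whether any of them would go beyond the scatter relative to hydrogen. They also leave open whether the gap between the 3-fluorobenzyl and 3-methylbenzyl groups would appear again on a different core, since one pair of compounds cannot establish a trend.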